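A Second Chlorine on the Benzyl Ring

The compounds below may be only part of what the source reports. "The series", "measured", "known", "first", "only" and "open" are said of these compounds alone.

Measured so far in an assay for inhibition of MAP kinase-interacting serine/threonine-protein kinase 1 (Homo sapiens), read by luminescence and ADP-Glo, with a stated time of 2 h; a higher number here means a weaker inhibitor, a lower number a stronger inhibitor:
compound 1, `CC(=O)Nc1cccc(Cn2cc(-c3ccc4cn[nH]c4c3)ccc2=O)c1`: 163 nM
compound 2, `O=c1ccc(-c2ccc3cn[nH]c3c2)cn1Cc1cccc(Cl)c1`: 37 nM

Compound 2 stands lowest of the two numbers in this assay; its nearest is compound 1, and the step of a 4.4-fold lower number from compound 1 to compound 2 (0.64 log units; beyond the scatter) was modest. Compound 3, `O=c1ccc(-c2ccc3cn[nH]c3c2)cn1Cc1ccc(Cl)c(Cl)c1`, differs from compound 2 by chloro in place of hydrogen on an aromatic carbon. Within the data shown here, no measured step shows a chloro entering in place of hydrogen; the only measured step, a 4.4-fold lower number from compound 1 to compound 2 (0.64 log units; beyond the scatter), swapped one group for another and bears only loosely on this change. The step of a 1.2-fold lower number from compound 2 to compound 3 (0.09 log units; within the scatter) is therefore expected to be small, hardly beyond the scatter. Compound 3 is estimated at 30 nM, with a range from 12 nM to 80 nM.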

Compound 3, half-maximal inhibitory concentration: 62 nM
For compound 3 the middle estimate is 2.1-fold (0.32 log units) below the measured one, and the stated range covers the measured number.
By their numbers in this assay, from the lowest: compounds 2 and 3 (each within the scatter of the next); then compound 1.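

In this assay, among these compounds, chloro in place of hydrogen, taking 3-chlorophenyl to 3,4-dichlorophenyl, gives a 1.7-fold higher number from compound 2 to compound 3 (0.22 log units; within the scatter), the first measured step of this kind. A second chlorine on this aromatic carbon, ortho to a chloro group and para to a large group, thus gives a number that cannot be told apart from that of compound 2. No evidence at hand bears on this result. The compounds shown leave open whether an amine, a methoxy group or a carboxylic acid on this same carbon would read alike, and whether the same chloro would do so without the chloro group already present in compound 2.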